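Aryl swap on the shared core: compound 1 to compound 3

The source may hold more compounds than are shown below. What is called first, only, known or untested is meant among the compounds shown, and "the series" means these compounds.

Compound 1 `CN1CCN(c2nc(-c3cc(Cl)ccc3Cl)nc3[nH]cnc23)CC1` in an assay on cells for displacement of a labelled ligand from adenosine receptor A3 (Homo sapiens), read by scintillation counting and radioligand binding, with a stated time of 180 min (a lower number here means a stronger inhibitor, a higher number a weaker inhibitor), gives 251 nM. Within the data shown here, only one other number is available: compound 2 `Clc1ccc(Cl)c(-c2nc(N3CCCCC3)c3nc[nH]c3n2)c1` gives 200 nM, and the step of a 1.3-fold lower number from compound 1 to compound 2 (0.10 log units; within the scatter) stays within the scatter, so the two cannot be ranked against each other. Compound 3 `CN1CCN(c2nc(-c3cccc(O)c3)nc3[nH]cnc23)CC1` is the next candidate. Its difference from compound 1 is 3-hydroxyphenyl in place of 2,5-dichlorophenyl on an aromatic carbon, on the aromatic carbon between two ring nitrogen atoms of the shared core. Among the measured compounds shown here, the single measured step, from compound 1 to compound 2, alters the amine and leaves the aryl group untouched, so no measured step bears on this change and no direction can be read from the series. The expectation for compound 3 is therefore a value near compound 1 with a wide band: compound 3 is estimated at 400 nM, between 80 nM and 2000 nM. That corresponds to an expected step of a 1.6-fold higher number from compound 1 to compound 3 (0.20 log units; within the scatter).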

Compound 3, inhibition constant: 501 nM
Beside the measured number, compound 3's estimate is 1.3-fold (0.10 log units) below it, within the range that was stated.
By their numbers in this assay, from the lowest: compounds 2, 1 and 3 (each within the scatter of the next, the first and the last beyond it).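

On the aromatic carbon between two ring nitrogen atoms of the shared core, the aryl group can be exchanged with a step of a 2.0-fold higher number from compound 1 to compound 3 (0.30 log units; within the scatter) in this assay, so 3-hydroxyphenyl and 2,5-dichlorophenyl cannot be ranked against each other. The entering group carries 1 hydrogen-bond donor and 1 hydrogen-bond acceptor, the leaving group neither, and both chlorine atoms are gone, yet the two compounds remain inseparable at this position. No measurement available here accounts for this outcome.

Among these compounds, the aryl exchange has been seen only with the 4-methylpiperazin-1-yl group in place, so its course alongside piperidin-1-yl remains open. Also open, from the compounds shown here alone, is how this position responds to 3-methoxyphenyl, 3-aminophenyl or a phenyl ring carrying a carboxylic acid.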